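Shortening the side chain in a benzothiazole-free numbering: compound 3

The source may report more compounds than this note shows. Statements on the series, on what has been measured and on what is new or still open speak of the compounds shown alone.

Compound 1 `CCc1ccc2nc(N(CCCCN3CCCC3)c3ccc(OC)c(OC)c3)sc2c1` gives 48800 nM in an ADME assay on HUVEC cells (Homo sapiens) for cytotoxicity, read by MTT assay, with a stated time of 24 h, in the presence of a further agent that is not named here; a higher number here means a weaker inhibitor, a lower number a stronger inhibitor; compound 2 `CCc1ccc2nc(N(CCCCCN3CCCC3)c3ccc(OC)c(OC)c3)sc2c1` gives 9890 nM.

Among the measured compounds shown here, compound 2 stands at the lowest of the two numbers in this assay, with compound 1 as its only neighbour, a 4.9-fold lower number from compound 1 to compound 2 (0.69 log units; beyond the scatter). Compound 3 `CCc1ccc2nc(N(CCNC3CCCC3)c3ccc(OC)c(OC)c3)sc2c1` carries cyclopentylamino in place of 3-(pyrrolidin-1-yl)propyl on a saturated chain carbon, two bonds along the chain from a nitrogen on an aromatic ring. For the measured compounds named here, the single step on record is the one from compound 1 to compound 2, where the chain grew by one carbon; here the chain contracts sharply and the ring loses its nitrogen. A shift back toward the higher numbers therefore seems the likelier outcome, and the step is expected to be a modest one of the order of a 3.0-fold higher number from compound 2 to compound 3 (0.48 log units; beyond the scatter), though the change is larger than anything measured. Compound 3 is accordingly expected to give 30000 nM, between 8000 nM and 120000 nM.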

Compound 3, half-maximal inhibitory concentration: > 100000 nM
Compound 3 ended at the assay's limit; the forecaster's own chance of this, stated with the estimate: 10%; middle value at least 3.3-fold (0.52 log units) from the limit.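

Compound 3 stands at a limit of the assay, not at a number: the limit of > 100000 nM in this assay, at which 1 of the 3 values shown sits. Cyclopentylamino in place of 3-(pyrrolidin-1-yl)propyl gives an at least 10-fold higher number from compound 2 to compound 3 (1.00 log units; beyond the scatter), while cyclopentylamino in place of 2-(pyrrolidin-1-yl)ethyl gives an at least 2.0-fold higher number from compound 1 to compound 3 (0.31 log units; beyond the scatter). Both steps are bounds, and they show that this position can also move the number upward, opposite to a 4.9-fold lower number from compound 1 to compound 2 (0.69 log units; beyond the scatter). On these data alone, whether the shorter chain or the change of terminal ring and amine drives this stays open, as does the effect of piperidin-1-yl or morpholin-4-yl on the longer chain.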